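This account rests on a few compounds, and the source may have more. Where it says the series, first, only, none or still open, it means among the compounds named here.

Compound 1 `Cc1ccc(-c2cc(C(=O)Nc3ccnc(Cl)c3)nn2-c2ccc3ccccc3n2)cc1`: 1600 nM
Compound 2 `COc1ncccc1NC(=O)c1cc(-c2ccc(C)cc2)n(-c2ccc3ccccc3n2)n1`: 7900 nM

Among the measured compounds shown here, in a functional assay on Huh-7 cells (Homo sapiens) for cytotoxicity, read by sulforhodamine B assay, with a stated time of 72 h (a higher number here means a weaker inhibitor, a lower number a stronger inhibitor), compound 2 gives 7900 nM, the highest of the two numbers; its nearest neighbour is compound 1 at 1600 nM, and the only measured step, a 4.9-fold higher number from compound 1 to compound 2 (0.69 log units; beyond the scatter), is a modest rise beyond the scatter. Compound 3 `Cc1ccc(-c2cc(C(=O)Nc3ncc(Br)cc3Br)nn2-c2ccc3ccccc3n2)cc1` differs from compound 2 by 3,5-dibromopyridin-2-yl in place of 2-methoxypyridin-3-yl on an amide-type nitrogen. This puts a halogen-bearing pyridinyl back on the amide nitrogen, loosely mirroring compound 1, so the step of a 2.6-fold lower number from compound 2 to compound 3 (0.42 log units; beyond the scatter) is expected to fall the number by a modest amount. Compound 3 is estimated at 3000 nM, with a range from 1000 nM to 9000 nM.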

Compound 3, half-maximal inhibitory concentration: 11500 nM
Beside the measured number, compound 3's estimate is 3.8-fold (0.58 log units) below it; the measured number lies above the stated range.
By their numbers in this assay, from the lowest: compound 1; then compounds 2 and 3 (each within the scatter of the next).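

In this assay, 3,5-dibromopyridin-2-yl in place of 2-methoxypyridin-3-yl on the amide-type nitrogen gives a 1.5-fold higher number from compound 2 to compound 3 (0.16 log units; within the scatter), so these two groups cannot be told apart here. Set against 2-chloropyridin-4-yl, the same group gives a 7.2-fold higher number from compound 1 to compound 3 (0.86 log units; beyond the scatter), so among these compounds a halogen on the pyridine does not by itself keep the lower number. No measurement at hand explains this difference. On these data alone, whether the lower number of compound 1 goes with its chlorine or with how its pyridine is attached stays open, as does what an amine on that pyridine would give.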